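The compounds below may be only part of what the source reports. "The series", "measured", "known", "first", "only" and "open" are said of these compounds alone.

Compound 1 `COc1cc2c(Oc3ccc(NC(=O)c4nn(-c5ccccc5C)cc(C)c4=O)c(F)c3)ccnc2cc1OCCCCCCC(=O)NO` gives 2300 nM in a functional assay on HCT-116 cells (Homo sapiens) for inhibition, read by MTT assay, with a stated time of 72 h; a lower number here means a stronger inhibitor, a higher number a weaker inhibitor. Compound 2 `COc1cc2c(Oc3ccc(NC(=O)c4nn(-c5ccccc5C)ccc4=O)cc3F)ccnc2cc1OCCCC(=O)NO` gives 3980 nM in this assay. Compound 3 `COc1cc2c(Oc3ccc(NC(=O)c4nn(-c5ccccc5C)cc(C)c4=O)cc3F)ccnc2cc1OCCCC(=O)NO` gives 2040 nM in this assay.

Compound 2 differs from compound 3 by hydrogen in place of methyl on an aromatic carbon, and in this assay that step was a 2.0-fold higher number from compound 3 to compound 2 (0.29 log units; within the scatter). Compound 1 and compound 3 share the same change-bearing ring but differ elsewhere; the difference between the two cores is not broken down here, and their values in this assay are within the scatter of each other.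

Compound 4 `COc1cc2c(Oc3ccc(NC(=O)c4nn(-c5ccccc5C)ccc4=O)c(F)c3)ccnc2cc1OCCCCCCC(=O)NO` has not yet been measured. It differs from compound 1 by hydrogen in place of methyl on an aromatic carbon, the same change as that from compound 3 to compound 2, at a place described in the same words. Because the earlier step was a 2.0-fold higher number from compound 3 to compound 2 (0.29 log units; within the scatter), a step of similar size is expected from compound 1 to compound 4, namely a 1.8-fold higher number from compound 1 to compound 4 (0.26 log units; within the scatter). Compound 4 is therefore estimated at 4200 nM in this assay, with an expected range from 2100 nM to 8400 nM.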

Compound 4, half-maximal inhibitory concentration: 4390 nM
Compound 4: the middle estimate sits 1.0-fold (0.02 log units) below what was measured; the measured number falls inside the stated range.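

In this assay, putting hydrogen in place of methyl on an aromatic carbon gave a 1.9-fold higher number from compound 1 to compound 4 (0.28 log units; within the scatter). The change carried over from one core to the other with much the same size: the same change on two cores in this assay, a 2.0-fold higher number (0.29 log units; within the scatter) from compound 3 to compound 2 and a 1.9-fold higher number (0.28 log units; within the scatter) from compound 1 to compound 4, 1.0-fold (0.01 log units) apart, within the scatter of two such steps This does not show that the change has a real effect on either core, since each step lies within the scatter, and two cores say nothing about other cores in the series.

The compounds shown carry only methyl or hydrogen at this place, so it remains open how an ethyl group, a chlorine or an amine there would read. Compound 1 and compound 3 also differ in more than one place, which leaves the contribution of the chain bearing the hydroxamic acid unseparated from that of the fluorine.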